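Swapping a phenyl for pyridin-3-yl on a purine-like core

This account rests on a few compounds, and the source may have more. Where it says the series, first, only, none or still open, it means among the compounds named here.

Compound 1, `Cn1c(-c2ccccc2)nc2c(NC3CCCC3)ncnc21`, is measured in an assay on CHO cells for displacement of a labelled ligand from adenosine receptor A1 (Homo sapiens), read by scintillation counting, with a stated time of 3 h (on this read-out higher numbers stand for weaker inhibition and lower numbers for stronger inhibition), where compound 1 gives 2.8 nM. Its close relative compound 2, `CCn1c(-c2ccccc2)nc2c(NC3CCCC3)ncnc21`, carries an ethyl in place of the methyl on the ring nitrogen, and in this assay compound 2 gives 3.9 nM. For the measured compounds named here, the only step measured so far, a 1.4-fold higher number from compound 1 to compound 2 (0.14 log units; within the scatter), is within the scatter, so compound 1 and compound 2 cannot be told apart on these numbers, and compound 1 simply stands at one of two very similar values.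

Compound 3, `Cn1c(-c2cccnc2)nc2c(NC3CCCC3)ncnc21`, keeps everything else and changes the aromatic ring hanging off the five-membered ring: pyridin-3-yl in place of phenyl on an aromatic carbon. Going by the values given here, no measured step touches this part of the molecule, so nothing here says how this assay responds to a ring nitrogen in that place. Among the compounds with values here, the single known step concerns a different position and offers no guide. On that basis only a cautious expectation is possible: a small step, a 2.1-fold higher number from compound 1 to compound 3 (0.33 log units; beyond the scatter), is expected, leaning toward a slightly higher number. Compound 3 is therefore estimated at 6 nM, with a range from 2 nM to 25 nM.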

Compound 3, inhibition constant: 242 nM
The estimate for compound 3 lay 40-fold (1.61 log units) below the measured number; measured number outside the range, above it.
By their numbers in this assay, from the lowest: compounds 1 and 2 (each within the scatter of the next); then compound 3.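

In this assay, the aromatic carbon between two ring nitrogen atoms proves highly sensitive to the group it carries: pyridin-3-yl in place of phenyl gives an 86-fold higher number from compound 1 to compound 3 (1.94 log units; beyond the scatter). The swap changes little on paper, since both rings have the same number of heavy atoms and neither carries a net charge; one ring carbon becomes nitrogen, which adds one hydrogen-bond acceptor, and that single edit produces a far larger step than the change on the ring nitrogen, a 1.4-fold higher number from compound 1 to compound 2 (0.14 log units; within the scatter). Nothing available here shows what lies behind this large step.

The compounds shown leave open whether any ring nitrogen in this group has the same effect, as a pyridin-2-yl or pyridin-4-yl group would test, or whether the result is specific to pyridin-3-yl. They also leave open how this position would respond to a phenyl ring bearing an amine or a hydroxyl group, and whether the same swap on the ethyl compound, compound 2, would produce a step of similar size.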